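The source may hold more compounds than are shown below. What is called first, only, known or untested is meant among the compounds shown, and "the series" means these compounds.

Measured so far:
Compound 1 `CC(C)NCC(=O)NCC(=O)N(C)c1ccc(Cl)cc1C(=O)c1ccccc1Cl`: 1 mg/kg
Compound 2 `CCCC(=O)NCC(=O)N(C)c1ccc(Cl)cc1C(=O)c1ccccc1Cl`: 0.98 mg/kg

For the measured compounds named here, in a functional assay on the whole organism for antagonist activity, with Mus musculus as the target (on this read-out lower numbers stand for an effect already at smaller amounts and higher numbers for an effect only at larger amounts of compound), compound 2 gives 0.98 mg/kg, level with the only other measured compound. The move between them is a 1.0-fold lower number from compound 1 to compound 2 (0.01 log units; within the scatter), so neither can be ranked above the other.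

The next compound is compound 3 `CCCCC(=O)NCC(=O)N(C)c1ccc(Cl)cc1C(=O)c1ccccc1Cl`, which lengthens the chain of compound 2 by a single carbon: methyl in place of hydrogen on a saturated chain carbon, three bonds along the chain from a carbonyl carbon. This places methyl in place of hydrogen on a saturated chain carbon, three bonds along the chain from a carbonyl carbon.

Going by the values given here, only one measured step touches this chain, a 1.0-fold lower number from compound 1 to compound 2 (0.01 log units; within the scatter). That is thin evidence, but it gives no sign that this assay responds strongly to changes here. No shift beyond the scatter is therefore expected, and the estimated step is a 1.0-fold higher number from compound 2 to compound 3 (0.01 log units; within the scatter). For compound 3 the expected value is 1 mg/kg, with an estimated range from 0.4 mg/kg to 2.5 mg/kg.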

Compound 3, dose for half-maximal effect: 1.3 mg/kg
Beside the measured number, compound 3's estimate is 1.3-fold (0.11 log units) below it; the range from low to high includes it.
By their numbers in this assay, from the lowest: compounds 2, 1 and 3 (each within the scatter of the next).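

Extending the chain by one methyl on a saturated chain carbon, three bonds along the chain from a carbonyl carbon, gives a 1.3-fold higher number from compound 2 to compound 3 (0.12 log units; within the scatter) in this assay and so adds a first test of chain length at this site. With propyl in place of isopropylamino, the reading is a 1.3-fold higher number from compound 1 to compound 3 (0.11 log units; within the scatter) and this second comparison also shows no separation, so the three side chains cannot be ranked on this read-out. No measured evidence bears on this result.

The compounds shown leave open how a much longer chain, such as octyl, or a carboxylic acid at the end of this chain would read. They also leave open whether the response stays this level beyond these three side chains.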